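From bromo to trifluoromethyl on the shared core

The source may hold more compounds than are shown below. What is called first, only, known or untested is meant among the compounds shown, and "the series" means these compounds.

In an ADME assay on Vero cells (Chlorocebus sabaeus) for cytotoxicity, read by resazurin assay, with a stated time of 72 h (a lower number here means that less compound is tolerated, a higher number that more compound is tolerated), compound 1 (`NC(=[Se])N/N=C/c1cccc(Br)c1`) gives 172000 nM and compound 2 (`NC(=[Se])N/N=C/c1ccc(Cl)c(Cl)c1`) gives 95100 nM as its reading, so the two numbers lie within the scatter of each other. Compound 3 (`NC(=[Se])N/N=C/c1cccc(C(F)(F)F)c1`) carries trifluoromethyl in place of bromo on an aromatic carbon and still awaits measurement. For the measured compounds named here, no step between measured compounds is available as a guide, so no shift beyond the scatter is expected in this assay here. The expected change is a 1.2-fold lower number from compound 1 to compound 3 (0.09 log units; within the scatter) and it is estimated to stay within the scatter. For compound 3 the estimated value is 140000 nM with an expected range from 60000 nM to 320000 nM in this measurement.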

Compound 3, half-maximal cytotoxic concentration: 167000 nM
The estimate for compound 3 lay 1.2-fold (0.08 log units) below the measured number, within the range that was stated.
By their numbers in this assay, from the lowest: compounds 2, 3 and 1 (each within the scatter of the next).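

For the compounds shown here, this is the first step on the shared core that changes only one place: in this assay, trifluoromethyl in place of bromo on an aromatic carbon gives a 1.0-fold lower number from compound 1 to compound 3 (0.01 log units; within the scatter) and stays within the scatter. At this position, the assay does not tell the two groups apart. No measurement at hand offers an explanation for this result.

From the compounds shown here alone, whether an amine, a carboxylic acid or a methoxy group at this aromatic carbon would move the number beyond the scatter remains open. So does whether trifluoromethyl and bromo would also match elsewhere on the ring.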